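Swapping one amine side chain for another on two related cores

A few compounds are considered here, and "the series" means these few. Any claim that something is new, unique, unknown or untested is made for them only; others in the source may bear on it.

Compound 1 `CN(C)CCN(CCN(C)C)c1ccc(C(=O)N2CCc3ccc(OS(N)(=O)=O)cc3C2)cc1` and compound 2 `CC(C)CCN(CCC(C)C)c1ccc(C(=O)N2CCc3ccc(OS(N)(=O)=O)cc3C2)cc1` share one core and differ in a single spot: diisopentylamino in place of bis(2-(dimethylamino)ethyl)amino on an aromatic carbon In an assay on HEK293 cells for inhibition of Steryl-sulfatase (Homo sapiens), tested at 0.1 uM (on this read-out lower numbers stand for a weaker effect and higher numbers for a stronger effect at the one concentration tested), compound 1 gives 3.8%, while compound 2 gives 47%, so the change made a step of a number 43.2 percentage points higher from compound 1 to compound 2 (beyond the scatter). Compound 3 `CN(C)CCN(CCN(C)C)c1cccc(C(=O)N2CCc3ccc(OS(N)(=O)=O)cc3C2)c1` has the same atoms as compound 1 joined differently; how the two cores differ is not broken down here. In this assay compound 3 gives 0%. Compound 4 `CC(C)CCN(CCC(C)C)c1cccc(C(=O)N2CCc3ccc(OS(N)(=O)=O)cc3C2)c1` stands to compound 3 as compound 2 stands to compound 1: diisopentylamino in place of bis(2-(dimethylamino)ethyl)amino on an aromatic carbon The change is the same kind of change, not the same, since in the first pair the group sits para to a large group and in the second pair meta to a large group. Because the step of a number 43.2 percentage points higher from compound 1 to compound 2 (beyond the scatter) was large, a step of similar direction is expected from compound 3 to compound 4, namely a number 35 percentage points higher from compound 3 to compound 4 (beyond the scatter), with the uncertainty that the place differs. Compound 4 is therefore estimated at 35%, between 10% and 60%.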

Compound 4, a percentage reported as inhibition, at one concentration (the size of the read-out at that concentration, not a potency): 32.3%
Beside the measured number, compound 4's estimate is 2.7 percentage points above it; measured number inside the range.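

In this assay, replacing bis(2-(dimethylamino)ethyl)amino with diisopentylamino on the second core gives a number 32.3 percentage points higher from compound 3 to compound 4 (beyond the scatter), so the change points the same way on both cores. Its size also carries over, as far as these measurements can tell: the same change on two cores in this assay, a number 43.2 percentage points higher (beyond the scatter) from compound 1 to compound 2 and a number 32.3 percentage points higher (beyond the scatter) from compound 3 to compound 4, 10.9 percentage points apart, within the scatter of two such steps. This rests on just two matched pairs, each tested at a single concentration, so it shows neither how potency changes nor whether the step would hold on any other core, and it gives no reason for the step.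

The compounds shown also leave open whether both side chains must change, which a mixed amine bearing one isopentyl chain and one 2-(dimethylamino)ethyl chain would help to settle. As far as these compounds go, it also remains open how the step would look with other amines on the same aromatic carbon, such as dipropylamino, a longer dihexylamino or a piperidine ring.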